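Swapping the Heterocycle on an Exocyclic Allyl Linker

The source may hold more compounds than are shown below. What is called first, only, known or untested is meant among the compounds shown, and "the series" means these compounds.

Compound 1 `Nc1ncn(CCC2(N)OC(=O)C(OCc3ccccc3)=C2OCc2ccccc2)c(=O)n1` — a functional assay on SW-620 cells (Homo sapiens) for inhibition, read by MTT assay, with a stated time of 72 h; on this read-out lower numbers stand for stronger inhibition and higher numbers for weaker inhibition: > 100000 nM.
Compound 2 `O=C1O/C(=C\Cn2ncc(=O)[nH]c2=O)C(OCc2ccccc2)=C1OCc1ccccc1` — this assay : 36500 nM.

For compound 1 the value is a limit of the assay rather than a number; it sits at the limit of > 100000 nM in this assay, at which 1 of the 2 values shown sits. Compound 2 gives the only number shown in this assay, so it stands alone there, with no step to another measured compound available for comparison.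

Compound 3 `Nc1ncn(C/C=C2\OC(=O)C(OCc3ccccc3)=C2OCc2ccccc2)c(=O)n1` is derived from compound 2 by a group of 8 heavy atoms (3 carbon, 4 nitrogen, 1 oxygen; one six-membered aromatic ring with 3 hetero atoms) in place of a group of 8 heavy atoms (3 carbon, 3 nitrogen, 2 oxygen; one six-membered aromatic ring with 3 hetero atoms), on a saturated chain carbon bound to a double-bonded chain carbon. Nothing measured bears directly on this exchange, so the step is uncertain in both direction and size. A step of a 1.4-fold higher number from compound 2 to compound 3 (0.14 log units; within the scatter) is expected, of a size that would sit within the usual scatter or a little beyond it towards weaker inhibition. Compound 3 is therefore estimated to give 50000 nM in this assay, with a range from 15000 nM to 150000 nM.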

Compound 3, half-maximal inhibitory concentration: 5620 nM
Estimate against measurement, compound 3: 8.9-fold (0.95 log units) above, and the stated range ends above it.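

Exchanging one six-membered aromatic ring with 3 hetero atoms for another, on a saturated chain carbon bound to a double-bonded chain carbon, gives a 6.5-fold lower number from compound 2 to compound 3 (0.81 log units; beyond the scatter) in this assay, so this position responds to which ring it carries. The two groups share 8 heavy atoms and 1 hydrogen-bond donor, yet the entering group has 5 hydrogen-bond acceptors against 4 and 1 double bond outside aromatic rings against 2, so a change this small in the ring is enough for a step beyond the scatter. This single pair cannot separate those differences, and nothing measured here accounts for the step.

As far as these compounds go, what a longer chain would do at this place remains open. So does the effect of a carboxylic acid or a methyl group on the ring.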